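Triazole-linked terpenoid esters that all sit at the ceiling

A few compounds are considered here, and "the series" means these few. Any claim that something is new, unique, unknown or untested is made for them only; others in the source may bear on it.

Compound 1 `COc1ccccc1-n1cc(COC(=O)/C(C)=C/CC/C(C)=C/CC/C(C)=C/CC[C@@H]2[C@@]3(C)CCC(=O)C(C)(C)[C@H]3CC[C@@]2(C)O)nn1`: in a functional assay on DU-145 cells (Homo sapiens) for antiproliferative activity, read by MTT assay, with a stated time of 48 h (a lower number here means a stronger inhibitor, a higher number a weaker inhibitor), compound 1 reaches only a limit, > 150000 nM.
Compound 2 `C/C(=C\CC/C(C)=C/CC[C@@H]1[C@@]2(C)CCC(=O)C(C)(C)[C@H]2CC[C@@]1(C)O)CC/C=C(\C)C(=O)OCc1cn(-c2ccccc2[N+](=O)[O-])nn1`: in this assay compound 2 likewise gives only a limit, > 150000 nM.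
Compound 3 `C/C(=C\CC/C(C)=C/CC[C@@H]1[C@@]2(C)CCC(=O)C(C)(C)[C@H]2CC[C@@]1(C)O)CC/C=C(\C)C(=O)OCc1cn(-c2ccc(Br)cc2)nn1`: in this assay compound 3 also gives only a limit, > 150000 nM.

On the numbers shown, compound 2 stands nowhere in particular: its value is a limit, and the two other values are limits as well, so nothing ranks compound 2 against compound 1 or compound 3. The piece follows the change from compound 2 to compound 4 `C/C(=C\CC/C(C)=C/CC[C@@H]1[C@@]2(C)CCC(=O)C(C)(C)[C@H]2CC[C@@]1(C)O)CC/C=C(\C)C(=O)OCc1cn(-c2ccc(C)cc2)nn1`, which is 4-methylphenyl in place of 2-nitrophenyl on an aromatic nitrogen.

Among the compounds with values here, three measured steps touch the same position on the shared core, and none of them can be read: a step that the two limits leave unreadable from compound 1 to compound 2, a step that the two limits leave unreadable from compound 1 to compound 3 and a step that the two limits leave unreadable from compound 2 to compound 3 are all unreadable because of the limit of > 150000 nM in this assay, at which 3 of the 3 values shown sit. Every swap of the aryl group on the triazole nitrogen tried so far, whether 2-methoxyphenyl, 2-nitrophenyl or 4-bromophenyl, has left the compound at the ceiling in this assay. For compound 4 no readable step in either direction is therefore expected, and the most probable outcome is once more a limit rather than a number.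

Compound 4 is expected to give about 200000 nM in this assay, with a range from 80000 nM to 600000 nM. The expected step is a step that the limit leaves unreadable from compound 2 to compound 4, which amounts to no change beyond the scatter.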

Compound 4, half-maximal inhibitory concentration: > 150000 nM
Compound 4: a limit, no number; the forecaster's own chance of this, stated with the estimate: 85%; the middle value lies beyond the limit too.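

In this assay compound 4 gives > 150000 nM as a limit, not a number. No step linking compound 4 to compound 1, compound 2 or compound 3 can be read, and the reason is this: the limit of > 150000 nM in this assay, at which 4 of the 4 values shown sit. The compounds shown leave open how these four rank against one another and whether any aryl group on the aromatic nitrogen gives a readable value in this assay at all.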